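Urea versus amide on the pyrazole series: compound 4

The source may report more compounds than this note shows. Statements on the series, on what has been measured and on what is new or still open speak of the compounds shown alone.

Measured so far:
- compound 1 `O=C(Nc1cccc(-n2cc(-c3ccncc3)c(-c3ccc(Cl)c(O)c3)n2)c1)Nc1ccc(Cl)c(Cl)c1`: 4470 nM
- compound 2 `COc1cc(-c2nn(-c3cccc(NC(=O)c4ccc(Cl)c(C(F)(F)F)c4)c3)cc2-c2ccncc2)ccc1Cl`: > 32500 nM
- compound 3 `O=C(Nc1cccc(-n2cc(-c3ccncc3)c(-c3ccc(Cl)c(O)c3)n2)c1)Nc1cc(C(F)(F)F)cc(C(F)(F)F)c1`: 1430 nM

In a functional assay on KM12 cells (Homo sapiens) for inhibition, read by sulforhodamine B assay, with a stated time of 48 h (on this read-out higher numbers stand for weaker inhibition of growth and lower numbers for stronger inhibition of growth), compound 1 gives 4470 nM and compound 3 gives 1430 nM; both carry a urea on the aniline. Compound 2 carries an amide instead, and in this assay compound 2 gives only a limit, > 32500 nM, which is not a number. That places compound 2 at the limit of > 32500 nM in this assay, at which 1 of the 3 values shown sits, the weakest point the data show for this series.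

Compound 4 `COc1cc(-c2nn(-c3cccc(NC(=O)Nc4cccc(C(F)(F)F)c4)c3)cc2-c2ccncc2)ccc1Cl` is not yet measured. Relative to compound 2 the change is (3-(trifluoromethyl)phenyl)amino in place of 4-chloro-3-(trifluoromethyl)phenyl on a carbonyl carbon, so compound 4 returns to the urea linkage seen in compound 1 and compound 3, while keeping the methoxy group of compound 2. The two measured ureas both sit well inside the numerical range of this assay, whereas the single amide does not; on that basis the step from compound 2 to compound 4 is expected to go toward stronger inhibition of growth, beyond the scatter, though it remains uncertain whether a number rather than a limit will be returned. For compound 4 the estimate is 9000 nM, within 2500 nM to 32500 nM, an expected step of an at least 3.6-fold lower number from compound 2 to compound 4 (0.55 log units; beyond the scatter).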

Compound 4, concentration for total growth inhibition: 1980 nM
Compound 4: middle estimate off by 4.5-fold (0.66 log units), on the high side; measured number outside the range, below it.
By their numbers in this assay, from the lowest: compounds 3 and 4 (each within the scatter of the next); then compound 1. At a limit, above all of these: compound 2.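

Going by these compounds alone, on the carbonyl carbon of the compound 2 scaffold, swapping 4-chloro-3-(trifluoromethyl)phenyl for (3-(trifluoromethyl)phenyl)amino gives the first one-place comparison in this set, and in this assay it is a large step: an at least 16-fold lower number from compound 2 to compound 4 (1.21 log units; beyond the scatter). The value for compound 2 is a limit and not a number: the limit of > 32500 nM in this assay, at which 1 of the 4 values shown sits. Compound 4 also shows that the methoxy group of compound 2 can sit on a urea that returns a number in this assay, whereas the two other ureas, compound 1 and compound 3, carry a hydroxy group there.

The swap changes two things at once, since it adds the amino nitrogen with its hydrogen-bond donor and also removes the chlorine, so the step cannot assign the change to either one; (4-chloro-3-(trifluoromethyl)phenyl)amino on the same carbonyl carbon would separate them. Also open, on these data alone, is whether the amino nitrogen itself matters, which a methylene in its place, giving a (3-(trifluoromethyl)phenyl)methyl group on the carbonyl carbon, would test.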